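Removing a Methyl from the Aryl Ketone of Compound 3

The source may hold more compounds than are shown below. What is called first, only, known or untested is meant among the compounds shown, and "the series" means these compounds.

The measured compounds:
Compound 1, `COc1cc(-c2nnc3n2NC(c2ccco2)C(C(=O)c2ccccc2F)S3)cc(OC)c1OC`: in a functional assay on PC-3 cells (Homo sapiens) for cytotoxicity, read by MTT assay, with a stated time of 48 h (on this read-out lower numbers stand for stronger inhibition and higher numbers for weaker inhibition), compound 1 reaches only the limit > 100000 nM, which is a bound of the assay and not a number.
Compound 2, `COc1cc(-c2nnc3n2NC(c2ccco2)C(C(=O)c2cccs2)S3)cc(OC)c1OC`: in this assay compound 2 gives 46200 nM.
Compound 3, `COc1cc(-c2nnc3n2NC(c2cccs2)C(C(=O)c2ccc(C)cc2)S3)cc(OC)c1OC`: in this assay compound 3 gives 5090 nM.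

Compound 3 therefore gives the lowest of the two numbers shown, with compound 2 the nearest, well beyond the scatter; compound 1 contributes only a limit (the limit of > 100000 nM in this assay, at which 1 of the 3 values shown sits). Compound 4, `COc1cc(-c2nnc3n2NC(c2cccs2)C(C(=O)c2ccccc2)S3)cc(OC)c1OC`, has not been measured. It differs from compound 3 by hydrogen in place of methyl on an aromatic carbon, that is, 4-methylphenyl becomes phenyl on the carbonyl carbon, so the (4-methylphenyl)carbonyl becomes benzoyl.

Among the measured compounds shown here, only one measured step touches the group on that carbonyl carbon: an at least 2.1-fold lower number from compound 1 to compound 2 (0.33 log units; beyond the scatter). That step swaps one ring for another and starts from a limit, so it shows that this position matters but not how a single methyl on the ring counts. For the measured compounds named here, with no closer precedent, the change from compound 3 to compound 4 is expected to be small, plausibly within the scatter, with a slight drift towards weaker inhibition left open: a 1.3-fold higher number from compound 3 to compound 4 (0.11 log units; within the scatter). Compound 4 is thus estimated at 6500 nM, within 2500 nM to 16000 nM.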

Compound 4, half-maximal inhibitory concentration: 86300 nM
Estimate against measurement, compound 4: 13-fold (1.12 log units) below; the whole stated range lies below it.
By their numbers in this assay, from the lowest: compound 3; then compounds 2 and 4 (each within the scatter of the next). At a limit, above all of these: compound 1.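

Taking away only the methyl from the 4-methylphenyl group of compound 3 has a large effect in this assay (a 17-fold higher number from compound 3 to compound 4 (1.23 log units; beyond the scatter)), so this single group on an aromatic carbon counts for much more than its size in the structure might suggest. The earlier step at this carbonyl swapped one whole ring for another and started from a limit, whereas this change is confined to one place and has a real number at both ends, which gives the first clean measure of what the methyl contributes here. Compound 1 still offers no number to set beside this, as its value is only a limit of the assay: the limit of > 100000 nM in this assay, at which 1 of the 4 values shown sits.

Going by these compounds, what remains open is whether a longer chain such as ethyl, or an amine or a carboxylic acid, in the same place on the ring would match compound 3, do better, or fall away as compound 4 does. The compounds shown also cannot tell whether the methyl would count for as much with a different group elsewhere on the shared core, and they give no reason for its effect.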